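Dropping the 3-methoxyphenyl from the ring nitrogen

A few compounds are considered here, and "the series" means these few. Any claim that something is new, unique, unknown or untested is made for them only; others in the source may bear on it.

Compound 2 `COc1cccc(N2C(=O)COc3ccc(-c4cccc(NS(=O)(=O)c5ccc(F)cc5)c4)cc32)c1` carries a 3-methoxyphenyl on an amide-type nitrogen in a ring. In a functional assay on A-375 cells (Homo sapiens) for antiproliferative activity, read by MTT assay, with a stated time of 72 h (a lower number here means a stronger inhibitor, a higher number a weaker inhibitor), compound 2 gives > 40000 nM, which is a limit of the assay and not a number. Compound 1 `O=C1COc2ccc(-c3cccc(NS(=O)(=O)c4ccc(F)cc4)c3)cc2N1` is the matching compound with hydrogen in that place, and in this assay compound 1 gives 20100 nM. The change between them is hydrogen in place of 3-methoxyphenyl on an amide-type nitrogen in a ring and it made an at least 1.9-fold lower number from compound 2 to compound 1 (0.29 log units; that floor lies within the scatter), a step that carries only a floor because compound 2 sits at the limit of > 40000 nM in this assay, at which 1 of the 3 values shown sits.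

Compound 3 `COc1cccc(N2C(=O)COc3ccc(-c4ccc(O)cc4)cc32)c1` has a different core, and the difference between the two cores is not broken down here; in this assay compound 3 gives 30400 nM. Compound 4 `O=C1COc2ccc(-c3ccc(O)cc3)cc2N1` is not yet measured. It differs from compound 3 by hydrogen in place of 3-methoxyphenyl on an amide-type nitrogen in a ring, the same change made from compound 2 to compound 1. For compound 4 in this assay a step of about a 1.8-fold lower number from compound 3 to compound 4 (0.25 log units; within the scatter) is expected, resting on the step from compound 2 to compound 1, an at least 1.9-fold lower number from compound 2 to compound 1 (0.29 log units; that floor lies within the scatter), whose floor is itself within the scatter. Compound 4 is therefore estimated at 17000 nM, with a range from 7000 nM to 40000 nM.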

Compound 4, half-maximal inhibitory concentration: > 40000 nM
Compound 4: only a limit was reported; the forecaster's own chance of this, stated with the estimate: 10%; middle value at least 2.3-fold (0.37 log units) from the limit.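

Compound 4 gives > 40000 nM in this assay, a limit of the assay and not a number, so hydrogen in place of 3-methoxyphenyl on this core yields only a floor: an at least 1.3-fold higher number from compound 3 to compound 4 (0.11 log units; that floor lies within the scatter). Set beside the earlier step, the result does not separate the two cores: the same change on two cores in this assay, an at least 1.9-fold lower number (0.29 log units; that floor lies within the scatter) from compound 2 to compound 1 and an at least 1.3-fold higher number (0.11 log units; that floor lies within the scatter) from compound 3 to compound 4; the limit leaves it open whether they differ. Neither step has a measured size, so the pair shows neither that the change carries from one core to the other nor that it fails to, and both steps rest on the same limit: the limit of > 40000 nM in this assay, at which 2 of the 4 values shown sit.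

The compounds shown leave open how large the step is on either core, since no matched pair here has numbers at both ends. They also leave open whether a methyl, or a longer chain ending in an amine, in that place on the ring nitrogen would give a number inside the range of this assay on either core.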